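A Difluorophenyl Swap on an Otherwise Unchanged Core

A few compounds are considered here, and "the series" means these few. Any claim that something is new, unique, unknown or untested is made for them only; others in the source may bear on it.

Compound 1 `C[C@H](Nc1nc(N)nc(N)c1C#N)c1cc(=O)n2cc(F)ccc2c1-c1ccccc1` has no result in an ADME assay on microsomes from liver (Rattus norvegicus), read by LC-MS, using NADPH, with a stated time of 30 min, tested at 1 uM; on this read-out higher numbers stand for a more stable compound and lower numbers for a less stable compound: its entry there is "not determined" (no result reported). A close relative, compound 2 `C[C@H](Nc1ncnc(N)c1C#N)c1cc(=O)n2cc(F)ccc2c1-c1ccccc1`, gives 74% in this assay. Compound 3 `C[C@H](Nc1nc(N)nc(N)c1C#N)c1cc(=O)n2cc(F)ccc2c1-c1cc(F)cc(F)c1` differs from compound 1 in one place: 3,5-difluorophenyl in place of phenyl on an aromatic carbon. Going by the values given here, no measured pair connects this change to a result, so the size of the move from compound 1 to compound 3 in this assay is unknown; no shift beyond the usual scatter is expected in either direction. Compound 3 is estimated at 72%, with a range from 45% to 95%.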

Compound 3, percent of the compound remaining: 87%
Compound 3: middle estimate off by 15 percentage points, on the low side; measured number inside the range.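

In this assay, going by these compounds alone, no step from compound 1 to compound 3 can be read. From the compounds shown here alone, what 3,5-difluorophenyl in place of phenyl does to this read-out stays open. Nothing shown offers an explanation for the result of compound 3.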